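Swapping fluoro for trifluoromethyl on compound 1

The compounds below may be only part of what the source reports. "The series", "measured", "known", "first", "only" and "open" are said of these compounds alone.

In a functional assay on HepG2 cells (Homo sapiens) for cytotoxicity, read by MTT assay, with a stated time of 24 h (on this read-out lower numbers stand for stronger inhibition and higher numbers for weaker inhibition), compound 1 (`Cc1ccc(S(=O)(=O)N2C/C(=C\c3cccnc3)C(=O)/C(=C/c3ccccc3F)C2)cc1`) gives 4200 nM and compound 3 (`CC(=O)Nc1ccc(S(=O)(=O)N2C/C(=C\c3cccnc3)C(=O)/C(=C/c3ccccc3F)C2)cc1`) gives 4560 nM as its number. These two lie within the scatter of each other and share the low end of the three values. Compound 2 (`O=C1/C(=C/c2cccnc2)CN(S(=O)(=O)c2ccc([N+](=O)[O-])cc2)C/C1=C\c1ccccc1F`) stands apart on the higher side at 12800 nM in the same test.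

Compound 4 (`Cc1ccc(S(=O)(=O)N2C/C(=C\c3cccnc3)C(=O)/C(=C/c3ccccc3C(F)(F)F)C2)cc1`) has not been measured yet. It differs from compound 1 by trifluoromethyl in place of fluoro on an aromatic carbon. Among the measured compounds shown here, no measured step touches that place. The three known steps all change a different group: nitro in place of methyl (a 3.0-fold higher number from compound 1 to compound 2 (0.48 log units; beyond the scatter)), acetamido in place of methyl (a 1.1-fold higher number from compound 1 to compound 3 (0.04 log units; within the scatter)) and acetamido in place of nitro (a 2.8-fold lower number from compound 2 to compound 3 (0.45 log units; beyond the scatter)). They are therefore only indirect guides, and they range from nothing beyond the scatter to modest. The expected step (a 1.1-fold higher number from compound 1 to compound 4 (0.03 log units; within the scatter)) is thus no shift beyond the scatter, though a modest move either way remains possible. Compound 4 is estimated at 4500 nM in this assay (range 1800 nM to 11000 nM).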

Compound 4, half-maximal inhibitory concentration: 2930 nM
Compound 4: middle estimate off by 1.5-fold (0.19 log units), on the high side; the measured number falls inside the stated range.
By their numbers in this assay, from the lowest: compounds 4, 1 and 3 (each within the scatter of the next); then compound 2.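

The earlier steps shown here all changed a different group, so this is the only one that speaks to the 2-fluorophenyl position. In this assay there is a 1.4-fold lower number from compound 1 to compound 4 (0.16 log units; within the scatter) when 2-(trifluoromethyl)phenyl replaces 2-fluorophenyl. Going from one heavy atom to four on this aromatic carbon, ortho to a large group, therefore leaves the number within the scatter, and no measurement shown gives a reason for this.

The compounds shown carry only fluoro and trifluoromethyl at this position, so it remains open whether a methoxy group, an amine or a carboxylic acid there would also leave the number in place. Going by these compounds, it is also open whether trifluoromethyl would behave the same way in the nitro and acetamido compounds, compound 2 and compound 3.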